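This account rests on a few compounds, and the source may have more. Where it says the series, first, only, none or still open, it means among the compounds named here.

Measured so far: compound 1 `CN1CCC(CNS(=O)(=O)c2ccccc2Nc2cc(-c3ccc4ccn(C)c4c3)c3nccnc3c2)C1`, 4640 nM; compound 2 `Cn1ccc2ccc(-c3cc(Nc4ccccc4S(N)(=O)=O)cc4nccnc34)cc21`, 37600 nM; compound 3 `Cn1cc(NC(=O)c2ccncc2Nc2cc(-c3ccc4ccn(C)c4c3)c3nccnc3c2)cn1`, 26500 nM.

In an assay on lysate for inhibition of 6-phosphofructo-2-kinase/fructose-2,6-bisphosphatase 3 (Homo sapiens), with stated times of 0.5 min and 45 min (a higher number here means a weaker inhibitor, a lower number a stronger inhibitor), compound 3 stands second highest of the three numbers; its gap to compound 2 lies within the scatter, while compound 1 sits a clearly lower number below it. Compound 4 `CN1CC(NC(=O)c2ccncc2Nc2cc(-c3ccc4ccn(C)c4c3)c3nccnc3c2)C1` differs from compound 3 in one place: 1-methylazetidin-3-yl in place of 1-methyl-1H-pyrazol-4-yl on an amide-type nitrogen. Within the data shown here, no measured step covers this exact exchange. Among the measured compounds shown here, the only step at hand, an 8.1-fold higher number from compound 1 to compound 2 (0.91 log units; beyond the scatter), shows that removing the (1-methylpyrrolidin-3-yl)methyl from the sulfonamide nitrogen weakened inhibition, so carrying a small saturated amine ring on the amide nitrogen in compound 4 may help, though a different core position and group make this a loose parallel. Compound 4 is therefore expected to show a modest step downward, a 2.2-fold lower number from compound 3 to compound 4 (0.34 log units; beyond the scatter), to an estimated 12000 nM in this assay, within 4000 nM to 35000 nM.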

Compound 4, half-maximal inhibitory concentration: 9190 nM
Beside the measured number, compound 4's estimate is 1.3-fold (0.12 log units) above it; the measured number falls inside the stated range.
By their numbers in this assay, from the lowest: compounds 1 and 4 (each within the scatter of the next); then compounds 3 and 2 (each within the scatter of the next).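

In this assay the substituent on the amide-type nitrogen is shown to matter: 1-methylazetidin-3-yl in place of 1-methyl-1H-pyrazol-4-yl gives a 2.9-fold lower number from compound 3 to compound 4 (0.46 log units; beyond the scatter) and is the only change at this place among the compounds shown. A four-membered non-aromatic ring thus serves better here than a five-membered aromatic ring, with one heavy atom fewer. Nothing measured here accounts for the step. The compounds shown leave open how a larger saturated ring such as 1-methylpiperidin-4-yl, or an open-chain 2-(dimethylamino)ethyl group, would fare on this nitrogen.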